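From 4-hydroxyphenyl to 2,6-dimethoxyphenyl

The compounds below may be only part of what the source reports. "The series", "measured", "known", "first", "only" and "open" are said of these compounds alone.

Values so far in a functional assay on MDA-MB-435 cells (Homo sapiens) for inhibition, read by sulforhodamine B assay, with a stated time of 48 h (a higher number here means a weaker inhibitor of growth, a lower number a stronger inhibitor of growth), for each compound
Compound 1 `O=C(Cc1csc2nc(-c3ccc(Br)cc3)cn12)N/N=C/c1ccccc1O`: 3310 nM
Compound 2 `O=C(Cc1csc2nc(-c3ccc(Br)cc3)cn12)N/N=C/c1ccc(O)cc1`: 6310 nM
Compound 3 `COc1cccc(OC)c1/C=N/NC(=O)Cc1csc2nc(-c3ccc(Br)cc3)cn12`: not yet measured

Among the measured compounds shown here, compound 2 at 6310 nM cannot be told apart from compound 1 on these numbers, since the only measured step is a 1.9-fold higher number from compound 1 to compound 2 (0.28 log units; within the scatter) and two compounds are too few to show a trend.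

Compound 3 keeps the shared core and differs in one place, on a carbon with a double bond to nitrogen, where 2,6-dimethoxyphenyl in place of 4-hydroxyphenyl on a carbon with a double bond to nitrogen is the change: 2,6-dimethoxyphenyl in place of 4-hydroxyphenyl.

For the measured compounds named here, the one step that bears on this place is a 1.9-fold higher number from compound 1 to compound 2 (0.28 log units; within the scatter) and it only swaps one hydroxyphenyl for another. Going by the values given here, no measured compound carries methoxy groups, so this is a weak guide. It gives no direction, and no step beyond the scatter is expected in this assay for now, though the uncertainty is wide.

The expected change is a 1.4-fold lower number from compound 2 to compound 3 (0.15 log units; within the scatter) and it could fall either way. Compound 3 is estimated at 4500 nM with an expected range from 1500 nM to 13000 nM for now.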

Compound 3, concentration for 50% growth inhibition: 3980 nM
Beside the measured number, compound 3's estimate is 1.1-fold (0.05 log units) above it; the range from low to high includes it.
By their numbers in this assay, from the lowest: compounds 1, 3 and 2 (each within the scatter of the next).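

In this assay, putting 2,6-dimethoxyphenyl on the carbon with a double bond to nitrogen gives a 1.6-fold lower number from compound 2 to compound 3 (0.20 log units; within the scatter) and, set against the other hydroxyphenyl compound, a 1.2-fold higher number from compound 1 to compound 3 (0.08 log units; within the scatter) as well. The earlier pair only swapped one hydroxyphenyl for another, whereas this change is larger: 4-hydroxyphenyl, with 7 heavy atoms and 1 hydrogen-bond donor, gives way to a group with 10 heavy atoms and 0 hydrogen-bond donors, yet all three compounds remain within the scatter of one another. Among these three compounds, then, a hydroxy group on this ring is not needed for growth inhibition in this range, although no measurement here explains why the numbers stay so close.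

Going by these compounds, no change at this place has yet moved the number beyond the scatter, so how much this position can influence growth inhibition remains unknown. A ring bearing a dimethylamino group or a carboxylic acid, or a plain phenyl ring with no oxygen-bearing group, would test whether the position responds to anything other than hydroxy and methoxy groups.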